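The source may hold more compounds than are shown below. What is called first, only, known or untested is meant among the compounds shown, and "the series" means these compounds.

Compound 1 `C/C(=N\Nc1nc(-c2ccccc2)cs1)c1ccc(Cl)c(Cl)c1`: > 50000 nM (a limit of the assay, not a number)
Compound 2 `C/C(=N\Nc1nc(-c2ccccn2)cs1)c1ccc(Cl)c(Cl)c1`: 10200 nM
Compound 3 `C/C(=N\Nc1nc(-c2ccncc2)cs1)c1ccc(Cl)c(Cl)c1`: 41900 nM

All three were tested in an ADME assay on H9c2 cells (Rattus norvegicus) for cytotoxicity, read by resazurin assay, with a stated time of 72 h; a higher number here means that more compound is tolerated, a lower number that less compound is tolerated. Of the two true numbers, compound 3 holds the higher, and the gap is a 4.1-fold higher number from compound 2 to compound 3 (0.61 log units; beyond the scatter). Compound 4 `C/C(=N\Nc1nc(-c2ccc(F)cc2)cs1)c1ccc(Cl)c(Cl)c1` carries 4-fluorophenyl in place of pyridin-4-yl on an aromatic carbon. The closest measured change is an at least 1.1-fold lower number from compound 1 to compound 3 (0.07 log units; that floor lies within the scatter), so phenyl and pyridin-4-yl are not clearly separated here. The larger at least 4.9-fold lower number from compound 1 to compound 2 (0.69 log units; beyond the scatter) concerns pyridin-2-yl, which compound 4 lacks. Among the measured compounds shown here, no measured compound carries fluorine. With that in mind, the expected change is small and stays within the scatter: a 1.0-fold lower number from compound 3 to compound 4 (0.02 log units; within the scatter). Compound 4 is estimated at 40000 nM, with an expected range from 15000 nM to 50000 nM.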

Compound 4, half-maximal cytotoxic concentration: > 50000 nM
Compound 4: only a limit was reported; the forecaster's own chance of this, stated with the estimate: 45%; at least 1.2-fold (0.09 log units) between middle value and limit.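

Among the compounds shown here, compound 4 is the first compound here with fluorine, and its value is a limit of the assay, not a number. With an at least 1.1-fold higher number from compound 3 to compound 4 (0.07 log units; that floor lies within the scatter), 4-fluorophenyl is not clearly separated from pyridin-4-yl at this position next to the ring nitrogen, but with an at least 4.9-fold higher number from compound 2 to compound 4 (0.69 log units; beyond the scatter), it is better tolerated than pyridin-2-yl. The step between compound 1 and compound 4 cannot be read because both values are limits: the limit of > 50000 nM in this assay, at which 2 of the 4 values shown sit.

From the compounds shown here alone, whether fluoro changes tolerance relative to hydrogen therefore remains open. So does how an amine or a carboxylic acid in place of fluoro would behave.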